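Dimethylamino in place of hydroxy on a piperidine amide

The source may report more compounds than this note shows. Statements on the series, on what has been measured and on what is new or still open speak of the compounds shown alone.

The shared core carries a substituted pyrazole on an aromatic nitrogen, and three compounds were tested in a physicochemical assay for solubility, at pH 7.4; on this read-out higher numbers stand for higher solubility and lower numbers for lower solubility. Compound 1 `C=CC(=O)Nc1cccc(-n2c(-c3nc(-c4cnn(C5CCN(C)CC5)c4)cnc3N)nc3ccccc32)c1` gives < 10000 nM, a limit of the assay rather than a number. Compound 2 `C=CC(=O)Nc1cccc(-n2c(-c3nc(-c4cnn(CCN5CCN(C)CC5)c4)cnc3N)nc3ccccc32)c1` gives 30000 nM, and an at least 3.0-fold higher number from compound 1 to compound 2 (0.47 log units; beyond the scatter). Compound 3 `C=CC(=O)Nc1cccc(-n2c(-c3nc(-c4cnn(C5CCN(C(=O)CO)CC5)c4)cnc3N)nc3ccccc32)c1` gives < 10000 nM, again a limit and not a number. Between these, an at least 3.0-fold lower number from compound 2 to compound 3 (0.47 log units; beyond the scatter), while a step that the two limits leave unreadable from compound 1 to compound 3; the limit is common, since (the limit of < 10000 nM in this assay, at which 2 of the 3 values shown sit).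

Compound 4 `C=CC(=O)Nc1cccc(-n2c(-c3nc(-c4cnn(C5CCN(C(=O)CN(C)C)CC5)c4)cnc3N)nc3ccccc32)c1` differs from compound 3 by dimethylamino in place of hydroxy on a saturated chain carbon bound to a carbonyl carbon. For the measured compounds named here, no measured step changes this position, so none bears directly on it; the only step beyond the scatter concerns a different substituent on the aromatic nitrogen. The number for compound 4 is therefore expected to stay near the limit of compound 3, with a modest upward allowance. For compound 4 the estimate is 12000 nM, between 3000 nM and 40000 nM. That estimate amounts to an expected step of an at least 1.2-fold higher number from compound 3 to compound 4 (0.07 log units; that floor lies within the scatter).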

Compound 4, solubility: 18000 nM
For compound 4 the middle estimate is 1.5-fold (0.18 log units) below the measured one; the range from low to high includes it.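

In this assay compound 3 gives < 10000 nM, which is a limit of the assay and not a number. Dimethylamino in place of hydroxy on this saturated chain carbon bound to a carbonyl carbon can be read only as a floor, an at least 1.8-fold higher number from compound 3 to compound 4 (0.25 log units; that floor lies within the scatter), and the start of an at least 1.8-fold higher number from compound 1 to compound 4 (0.25 log units; that floor lies within the scatter) is likewise a limit, so this position now shows a readable number where hydroxy showed none. Replacing the whole substituent on the aromatic nitrogen gives a 1.7-fold lower number from compound 2 to compound 4 (0.22 log units; within the scatter), which leaves these two compounds level within the scatter.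

Going by these compounds, how large the true step from hydroxy to dimethylamino is stays open, as its floor lies within the scatter. Also open, on these data alone, is how a morpholine, a longer chain carrying the amine or a carboxylic acid would read at this place.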